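The source may report more compounds than this note shows. Statements on the series, on what has been measured and on what is new or still open speak of the compounds shown alone.

Measured compounds in a functional assay on KG-1 cells (Homo sapiens) for cytotoxicity, read by luminescence and CellTiter-Glo, with a stated time of 3 days; on this read-out higher numbers stand for weaker inhibition and lower numbers for stronger inhibition:

compound 1, `Cc1cc(C#N)ccc1NC(=O)c1ccc2cccnc2c1O`, gives 3240 nM
compound 2, `N#Cc1ccc(NC(=O)c2ccc3cccnc3c2O)cc1`, gives 2320 nM
compound 3, `N#Cc1ccc(NC(=O)c2ccccc2O)cc1`, gives 5370 nM

Compound 2 and compound 1 share one core and differ in one place: methyl in place of hydrogen on an aromatic carbon. That change made a 1.4-fold higher number from compound 2 to compound 1 (0.15 log units; within the scatter). Compound 3 carries a different core; how the core of compound 3 differs from that of compound 2 is not broken down here. In this assay compound 3 stands at the highest number of the three measured, and against compound 2 the gap is beyond the scatter, while against compound 1 it is within the scatter.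

Compound 4, `Cc1ccc(O)c(C(=O)Nc2ccc(C#N)cc2)c1`, is not yet measured. It differs from compound 3 in one place: methyl in place of hydrogen on an aromatic carbon. Going by the values given here, this is the same kind of change as the one from compound 2 to compound 1, but not the same: there the methyl sits ortho to a large group and meta to a cyano group, here it sits meta to a large group and para to a hydroxy group, on the other ring of the molecule.

Among the compounds with values here, the only measured instance of this kind of change, from compound 2 to compound 1, stayed within the scatter. On that basis, and on nothing else, the step from compound 3 to compound 4 in this assay is expected to be small as well, about a 1.1-fold higher number from compound 3 to compound 4 (0.05 log units; within the scatter). Compound 4 is therefore estimated at 6000 nM, with a likely range from 2500 nM to 14000 nM, the width reflecting that the place of the methyl is different and that compound 3 already sits at the high end of the measured range.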

Compound 4, half-maximal inhibitory concentration: 3370 nM
Compound 4: the middle estimate sits 1.8-fold (0.25 log units) above what was measured, within the range that was stated.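

Methyl in place of hydrogen on an aromatic carbon made a 1.6-fold lower number from compound 3 to compound 4 (0.20 log units; within the scatter) in this assay, so this step is also small. Set beside the earlier step, it gives no sign that the outcome depends on the core: the same change on two cores in this assay, a 1.4-fold higher number (0.15 log units; within the scatter) from compound 2 to compound 1 and a 1.6-fold lower number (0.20 log units; within the scatter) from compound 3 to compound 4, 2.2-fold (0.35 log units) apart, within the scatter of two such steps

In this series and in this assay, the two pairs therefore support carrying the change from one core to the other with little expected effect on the number, but no direction can be assigned to either step, and the two pairs do not show that the result holds on other cores or at other places on the ring, since the methyl occupies a different place in each pair.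

Still open, going by these compounds, is whether a methyl at either place would give the same result if both places were compared on a single core. Also open, on these data alone, is whether the small steps are particular to methyl or would hold for an ethyl group, a longer chain, an amine or a carboxylic acid at the place meta to a large group and para to a hydroxy group.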